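The source may hold more compounds than are shown below. What is called first, only, known or untested is meant among the compounds shown, and "the series" means these compounds.

In an assay on membranes from HEK293 cells for displacement of a labelled ligand from Translocator protein (Homo sapiens), read by scintillation counting, with a stated time of 90 min (a higher number here means a weaker inhibitor, a lower number a stronger inhibitor), the three measured compounds share one outcome. Compound 1, `CCN(CC)C(=O)c1nc2ccccc2n1Cc1ccc(Cl)cc1`, gives only a limit of the assay, > 10000 nM. Compound 2, `CCN(CC)C(=O)c1cc2cc(C)ccc2n1Cc1ccc(OCc2ccccc2)cc1`, likewise gives only a limit, > 10000 nM. Compound 3, `CCN(CC)C(=O)c1cc2cc(C)ccc2n1Cc1ccc(O)cc1`, also gives only a limit, > 10000 nM. Hence the single step between measured compounds that differ in one place, a step that the two limits leave unreadable from compound 2 to compound 3, cannot be read, and its size stays unknown; compound 3 stands at the limit together with its two companions, as the limit of > 10000 nM in this assay, at which 3 of the 3 values shown sit, records.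

Compound 4, `CCN(CC)C(=O)c1cc2cc(C)ccc2n1Cc1cn[nH]n1`, differs from compound 3 by 2H-1,2,3-triazol-4-yl in place of 4-hydroxyphenyl on a saturated chain carbon bound to an aromatic nitrogen. No measured step bears on this change: the only step known, a hydrogen in place of a benzyl on the oxygen, has no readable size, and none of the shown compounds carries a five-membered aromatic ring with 3 hetero atoms at this place. With every shown value sitting at the limit, compound 4 is expected to return a limit as well, so that the step that the limit leaves unreadable from compound 3 to compound 4 is expected to remain within the scatter. The estimate for compound 4 in this assay is 12000 nM, with a range from 3000 nM to 50000 nM.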

Compound 4, inhibition constant: > 10000 nM
Compound 4: only a limit was reported; the forecaster's own chance of this, stated with the estimate: 80%; the middle value is on the limit's open side.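

Compound 3 and compound 4 each give only a limit in this assay, and no step can be read between them, nor any size for 2H-1,2,3-triazol-4-yl in place of 4-hydroxyphenyl. The compounds shown leave open which change to the shared core, if any, would give a readable value, with every compound at one mark: the limit of > 10000 nM in this assay, at which 4 of the 4 values shown sit.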